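The source may hold more compounds than are shown below. What is called first, only, known or untested is meant among the compounds shown, and "the series" means these compounds.

Series notes. Compound 1 `COc1ccc(OC)c(Sc2ccc3nnc(-c4ccccc4)n3n2)c1` gives 173 nM in an assay on isolated protein for inhibition of Leucine-rich repeat serine/threonine-protein kinase 2 (Homo sapiens), in the presence of a further agent that is not named here; on this read-out lower numbers stand for stronger inhibition and higher numbers for weaker inhibition. Compound 2 `COc1ccc(OC)c(Sc2ccc3nnc(-c4cccnc4)n3n2)c1` gives 242 nM in this assay, and compound 3 `COc1cncc(-c2nnc3ccc(Sc4cc(OC)ccc4OC)nn23)c1` gives 66 nM. The steps are a 1.4-fold higher number from compound 1 to compound 2 (0.15 log units; within the scatter), a 2.6-fold lower number from compound 1 to compound 3 (0.42 log units; beyond the scatter) and a 3.7-fold higher number from compound 3 to compound 2 (0.56 log units; beyond the scatter). The cores of compound 1 and compound 3 differ by phenyl in place of 5-methoxypyridin-3-yl on an aromatic carbon.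

Compound 4 `COc1ccccc1Sc1ccc2nnc(-c3ccccc3)n2n1` is not yet measured. It differs from compound 1 by hydrogen in place of methoxy on an aromatic carbon. The same kind of change runs from compound 3 to compound 2, (hydrogen in place of methoxy on an aromatic carbon), where the step was a 3.7-fold higher number from compound 3 to compound 2 (0.56 log units; beyond the scatter). The places are not identical: in compound 3 the methoxy leaves a six-membered aromatic ring with 1 nitrogen, two atoms from the ring nitrogen; in compound 1 it leaves a six-membered aromatic ring of carbon only, para to a methoxy group. Going by the values given here, only one instance of the change is measured, on a different ring, so the transfer is uncertain. A weakened, somewhat smaller step is expected, a 2.0-fold higher number from compound 1 to compound 4 (0.31 log units; beyond the scatter), resting on compound 3 to compound 2 a 3.7-fold higher number from compound 3 to compound 2 (0.56 log units; beyond the scatter). Compound 4 is estimated at 350 nM, from 150 nM to 850 nM.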

Compound 4, half-maximal inhibitory concentration: 1070 nM
Estimate against measurement, compound 4: 3.1-fold (0.49 log units) below; the measured number lies above the stated range.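

In this assay, hydrogen in place of methoxy gives a weaker number on both cores where the change can be read, and the new step is a 6.2-fold higher number from compound 1 to compound 4 (0.79 log units; beyond the scatter). The two instances of the change do not differ beyond what repeated measurement allows: the same change on two cores in this assay, a 3.7-fold higher number (0.56 log units; beyond the scatter) from compound 3 to compound 2 and a 6.2-fold higher number (0.79 log units; beyond the scatter) from compound 1 to compound 4, 1.7-fold (0.23 log units) apart, within the scatter of two such steps. This supports carrying the direction and rough size of the change between these two cores, but the methoxy leaves a different ring in each pair, so two steps show neither a general rule for the series nor a shared reason for the loss.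

The compounds shown leave open whether the weaker number follows the loss of the methoxy oxygen or of the whole group, which a hydroxyl, ethoxy or fluorine in the same place on the core of compound 1 would begin to separate. Also open, as far as these compounds go, is what the other methoxy on that ring contributes, since it stays in place in compound 4.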